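The source may hold more compounds than are shown below. What is called first, only, known or untested is meant among the compounds shown, and "the series" means these compounds.

Working notes on the diaryl thioether series

Of the compounds shown here, three carry numbers so far. Compound 1 `CNC(=O)c1ccc(Sc2ccc(NC(=S)Nc3ccc(F)c(F)c3)cc2)nc1` gives in a functional assay on HCT-116 cells (Homo sapiens) for cytotoxicity, read by MTT assay, with a stated time of 48 h (a lower number here means a stronger inhibitor, a higher number a weaker inhibitor), a value of 22200 nM. Compound 2 `CNC(=O)c1ccc(Sc2ccc(NC(=O)Nc3ccc(Cl)c(C(F)(F)F)c3)cc2)nc1`, which carries a urea rather than a thiourea, gives in this assay a value of 5290 nM. Compound 3 `CNC(=O)c1ccc(Sc2cccc(NC(=S)Nc3ccc(F)c(F)c3)c2)nc1`, with the thiourea attached at a different position of the central ring, gives in this assay a value of 35100 nM. Compound 3 therefore holds the highest number of the three; its gap to compound 1 lies within the usual scatter, so no order between those two can be read, while its gap to compound 2 lies beyond it, compound 2 showing the lower number.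

Compound 4 `CNC(=O)c1ccc(Sc2cccc(NC(=S)Nc3ccc(Cl)cc3)c2)nc1` has not yet been measured. It keeps the core of compound 3 and changes only the aryl on the thiourea: 4-chlorophenyl in place of 3,4-difluorophenyl on an amide-type nitrogen. For the measured compounds named here, no step between measured compounds bears on this change, so the expectation rests on compound 3 alone. The step from compound 3 to compound 4 in this assay is expected to be small, a 1.2-fold lower number from compound 3 to compound 4 (0.07 log units; within the scatter), in no direction that would exceed the scatter. Compound 4 is expected to give 30000 nM, in a range from 12000 nM to 75000 nM.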

Compound 4, half-maximal inhibitory concentration: 39500 nM
Estimate against measurement, compound 4: 1.3-fold (0.12 log units) below, within the range that was stated.
By their numbers in this assay, from the lowest: compound 2; then compounds 1, 3 and 4 (each within the scatter of the next).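

In this assay the aryl on the thiourea now has its first readable step: 4-chlorophenyl in place of 3,4-difluorophenyl on an amide-type nitrogen gives a 1.1-fold higher number from compound 3 to compound 4 (0.05 log units; within the scatter) and so leaves two numbers that the scatter cannot separate. On the core of compound 3, this aryl can therefore exchange two fluorines for one chlorine with no readable change in the assay, so the number seen for compound 3 is not specific to the 3,4-difluorophenyl group among the two aryl groups compared here. No measurement at hand bears on why these two aryl groups read alike, and this single step gives no basis for an explanation.

As far as these compounds go, whether a group of a different kind at this place, such as an aminophenyl, a carboxylic acid-bearing phenyl or a longer alkyl chain, would move the number beyond the scatter remains open. Also open, from the compounds shown here alone, is whether the same exchange of 4-chlorophenyl for 3,4-difluorophenyl would read alike on the core of compound 1, or on a urea in place of the thiourea.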